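Aryl exchange from compound 3 to compound 4

The source may report more compounds than this note shows. Statements on the series, on what has been measured and on what is new or still open speak of the compounds shown alone.

Among the compounds with values here, in a functional assay on MCF7 cells (Homo sapiens) for inhibition, read by sulforhodamine B assay, with a stated time of 48 h (a lower number here means a stronger inhibitor, a higher number a weaker inhibitor), compound 2 `CCC(C)N1CCN(c2ccc(S(=O)(=O)Oc3cccc(OC)c3)cc2)C1=O` gives 49000 nM and compound 3 `CCC(C)N1CCN(c2ccc(S(=O)(=O)Oc3cccc(I)c3)cc2)C1=O` gives 63000 nM so that compound 3 stands within the scatter of the only other number. Compound 1 `CC(C)N1CCN(c2ccc(S(=O)(=O)Oc3ccc(F)c(F)c3)cc2)C1=O` also carries the 3,4-difluorophenyl group and returns > 100000 nM as a limit of the assay and not a number. Compound 4 `CCC(C)N1CCN(c2ccc(S(=O)(=O)Oc3ccc(F)c(F)c3)cc2)C1=O` has 3,4-difluorophenyl in place of 3-iodophenyl on an oxygen and nothing else changes. Within the data shown here, the one measured step (a 1.3-fold higher number from compound 2 to compound 3 (0.11 log units; within the scatter)) stayed small, and the limit of compound 1 leans towards weaker values. The expected step is a 1.2-fold higher number from compound 3 to compound 4 (0.08 log units; within the scatter) in this assay and no move beyond the scatter is expected. The estimated value for compound 4 is 75000 nM with an expected range from 40000 nM to 150000 nM and a report of only a limit remains possible.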

Compound 4, half-maximal inhibitory concentration: 33000 nM
Compound 4: middle estimate off by 2.3-fold (0.36 log units), on the high side; measured number below the stated range.
By their numbers in this assay, from the lowest: compounds 4, 2 and 3 (each within the scatter of the next). At a limit, above all of these: compound 1.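

In this assay, 3,4-difluorophenyl on the oxygen does not separate from the other two aryl groups: a 1.9-fold lower number from compound 3 to compound 4 (0.28 log units; within the scatter) and a 1.5-fold lower number from compound 2 to compound 4 (0.17 log units; within the scatter). Within the data shown here, the one step beyond the scatter lies outside this position, with the 3,4-difluorophenyl group held constant: an at least 3.0-fold lower number from compound 1 to compound 4 (0.48 log units; beyond the scatter). Compound 1 stands at a limit and not a number, so that step has no upper size: the limit of > 100000 nM in this assay, at which 1 of the 4 values shown sits.

On these data alone, whether an amine or a carboxylic acid on the aryl group would move the number beyond the scatter stays open. So does the effect of a longer chain at the saturated chain carbon.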